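The source may hold more compounds than are shown below. What is called first, only, known or untested is meant among the compounds shown, and "the series" means these compounds.

Compound 3 `BrCc1cn(Cc2ccccc2)nn1` gives the lowest number shown in a functional assay on HeLa cells (Homo sapiens), read by colorimetric assay, with a stated time of 72 h; on this read-out higher numbers stand for an effect only at larger amounts of compound and lower numbers for an effect already at smaller amounts; its value is 2 ug/mL. Compound 2 `ClCc1cn(Cc2ccccc2)nn1` gives 18 ug/mL in this assay. Compound 1 `FCc1cn(Cc2ccccc2)nn1` gives only a limit of the assay, > 100 ug/mL, in this assay. Compound 4 `ICc1cn(Cc2ccccc2)nn1` differs from compound 3 by iodo in place of bromo on a saturated chain carbon bound to an aromatic carbon. Among the measured compounds every move to a heavier halogen in that place lowered the number: an at least 5.5-fold lower number from compound 1 to compound 2 (0.74 log units; beyond the scatter), an at least 50-fold lower number from compound 1 to compound 3 (1.69 log units; beyond the scatter) and a 9.0-fold lower number from compound 2 to compound 3 (0.95 log units; beyond the scatter). Going one halogen further, to iodo, the number for compound 4 is therefore expected to fall again, by a 2.9-fold lower number from compound 3 to compound 4 (0.46 log units; beyond the scatter). Compound 4 is estimated at 0.7 ug/mL, with a likely range from 0.2 ug/mL to 2.5 ug/mL.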

Compound 4, concentration for half-maximal effect: 2 ug/mL
Compound 4: the middle estimate sits 2.9-fold (0.46 log units) below what was measured; measured number inside the range.
By their numbers in this assay, from the lowest: compounds 3 and 4 (each within the scatter of the next); then compound 2. At a limit, above all of these: compound 1.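

In this assay the halogen series no longer tracks with the number at this position, with the last exchange giving no change at the digits printed from compound 3 to compound 4 (within the scatter). Iodo still stands clearly apart from chloro, with a 9.0-fold lower number from compound 2 to compound 4 (0.95 log units; beyond the scatter). The gap to fluoro, an at least 50-fold lower number from compound 1 to compound 4 (1.69 log units; beyond the scatter), is only a bound, since compound 1 gives no number but a limit: the limit of > 100 ug/mL in this assay, at which 1 of the 4 values shown sits. Open, from the compounds shown here alone, is how this carbon responds to a group that is not a halogen, such as an amine or a hydroxyl. Also open, going by these compounds, is whether a longer chain carrying bromo or iodo would keep these numbers.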